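Methoxy added to a dienone: cytotoxicity expectation

This account rests on a few compounds, and the source may have more. Where it says the series, first, only, none or still open, it means among the compounds named here.

Of the compounds shown here, three have been measured in a functional assay on HPC cells (Homo sapiens) for cytotoxicity; a lower number here means that less compound is tolerated, a higher number that more compound is tolerated. Compound 1 `COc1cc(/C=C2\Cc3ccccc3/C(=C\c3ccc([N+](=O)[O-])cc3)C2=O)ccc1O` gives 83000 nM, compound 2 `COc1ccc(/C=C2\CCC/C(=C\c3ccc([N+](=O)[O-])cc3)C2=O)cc1OC` gives 82000 nM, and compound 3 `O=C1/C(=C/c2ccc(O)cc2)Cc2ccccc2/C1=C\c1ccc([N+](=O)[O-])cc1` gives 113000 nM. Compound 1 differs from compound 3 by methoxy in place of hydrogen on an aromatic carbon, and the step is a 1.4-fold lower number from compound 3 to compound 1 (0.13 log units; within the scatter). The difference between the cores of compound 2 and compound 3 is not broken down here.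

Compound 4 `COc1cc(/C=C2\CCC/C(=C\c3ccc([N+](=O)[O-])cc3)C2=O)cc(OC)c1OC` has not yet been measured. It differs from compound 2 by methoxy in place of hydrogen on an aromatic carbon. This is the same kind of change as from compound 3 to compound 1, but the surroundings differ: in compound 1 the entering group sits ortho to a hydroxy group, while in compound 4 it sits ortho to a methoxy group and meta to a methoxy group. In this assay the step is expected to be a 1.1-fold lower number from compound 2 to compound 4 (0.04 log units; within the scatter), resting on a 1.4-fold lower number from compound 3 to compound 1 (0.13 log units; within the scatter). Compound 4 is therefore estimated at 75000 nM, with a range from 35000 nM to 160000 nM.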

Compound 4, half-maximal cytotoxic concentration: 347000 nM
The estimate for compound 4 lay 4.6-fold (0.67 log units) below the measured number; the whole stated range lies below it.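

In this assay, methoxy in place of hydrogen on an aromatic carbon did not carry over from one core to the other with a single size of step: the same change on two cores in this assay, a 1.4-fold lower number (0.13 log units; within the scatter) from compound 3 to compound 1 and a 4.2-fold higher number (0.63 log units; beyond the scatter) from compound 2 to compound 4, 5.8-fold (0.76 log units) apart, beyond the scatter of two such steps. Here, methoxy entering ortho to a methoxy group and meta to a methoxy group gave a 4.2-fold higher number from compound 2 to compound 4 (0.63 log units; beyond the scatter), so the earlier step offers no safe guide for this pair. The two pairs differ in the core and also in the other groups on the ring, and they do not show which of these accounts for the gap.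

The compounds shown leave open whether an ethoxy group or an amine in the same place would give a similar step. They also leave open whether the step seen here would recur on the core of compound 1.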